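From Methoxy to Bromo on the Benzyl Amide

The compounds below may be only part of what the source reports. "The series", "measured", "known", "first", "only" and "open" are said of these compounds alone.

Three compounds share one core and differ in the arm that carries a benzyl group. Compound 1 `C=C1CC[C@@H]2[C@](C)(CNCc3ccccc3)[C@H](O)CC[C@@]2(C)[C@@H]1/C=C/C1=CCOC1=O` and compound 2 `C=C1CC[C@@H]2[C@](C)(CNCc3ccc(C#N)cc3)[C@H](O)CC[C@@]2(C)[C@@H]1/C=C/C1=CCOC1=O` carry the benzyl on an amine, while compound 3 `C=C1CC[C@H]2[C@@](C)(CC[C@@H](O)[C@@]2(C)C(=O)NCc2ccc(OC)cc2)[C@@H]1/C=C/C1=CCOC1=O` carries a 4-methoxybenzyl on an amide. In a functional assay on BMMC cells (Mus musculus, strain C57BL/6) for inhibition, with stated times of 5 days and 48 h (a higher number here means a weaker inhibitor, a lower number a stronger inhibitor), compound 1 gives 960 nM, compound 2 gives 1130 nM, and compound 3 gives 6530 nM, the highest of the three numbers. Among the measured compounds shown here, the only change measured so far, a 1.2-fold higher number from compound 1 to compound 2 (0.07 log units; within the scatter), is small. Compound 4 `C=C1CC[C@H]2[C@@](C)(CC[C@@H](O)[C@@]2(C)C(=O)NCc2ccc(Br)cc2)[C@@H]1/C=C/C1=CCOC1=O` differs from compound 3 by bromo in place of methoxy on an aromatic carbon. For the measured compounds named here, no measured step concerns this pair directly: the step from compound 1 to compound 2 sits on an amine arm and exchanges hydrogen for cyano, not methoxy for bromo, and it shows only that one change on the benzyl ring left the number about where it was. The account therefore expects for compound 4 no step beyond the scatter, a 1.1-fold lower number from compound 3 to compound 4 (0.04 log units; within the scatter). Compound 4 is estimated at 6000 nM, with a range from 2500 nM to 15000 nM.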

Compound 4, half-maximal inhibitory concentration: 3450 nM
The estimate for compound 4 lay 1.7-fold (0.24 log units) above the measured number; low and high end bracket the measured number.
By their numbers in this assay, from the lowest: compounds 1 and 2 (each within the scatter of the next); then compounds 4 and 3 (each within the scatter of the next).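

On the amide arm, the aromatic carbon accepts bromo in place of methoxy without a step that can be told from the scatter, with a 1.9-fold lower number from compound 3 to compound 4 (0.28 log units; within the scatter) in this assay. With bromo in place, the amide compound still stands apart from both amine compounds, with a 3.1-fold higher number from compound 2 to compound 4 (0.48 log units; beyond the scatter) and a 3.6-fold higher number from compound 1 to compound 4 (0.56 log units; beyond the scatter), but these steps change both the arm and the ring group, so they do not separate the two changes. Nothing at hand gives a reason for any of these steps.

On these data alone, it remains open how a 4-bromobenzyl group would read on the amine arm, and an unsubstituted benzyl group on the amide arm. Also open, as far as these compounds go, is how fluoro, hydroxyl or a carboxylic acid would compare on the same aromatic carbon.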